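A few compounds are considered here, and "the series" means these few. Any claim that something is new, unique, unknown or untested is made for them only; others in the source may bear on it.

Compound 1 `COc1ccc(/C=C/C(=O)c2cc(-c3cc(OC)c(OC)c(OC)c3)n3nc(-c4ccccc4)cc3n2)cc1OC` gives 20500 nM in a functional assay on A549 cells (Homo sapiens) for antiproliferative activity, read by MTT assay, with a stated time of 24 h; on this read-out lower numbers stand for stronger inhibition and higher numbers for weaker inhibition.
Compound 2 `COc1ccc(/C=C/C(=O)c2cc(-c3cc(OC)c(OC)c(OC)c3)n3nc(-c4ccccc4)cc3n2)cc1` gives 21200 nM in this assay.
Compound 3 `COc1cc(-c2cc(C(=O)/C=C/c3ccc(C)cc3)nc3cc(-c4ccccc4)nn23)cc(OC)c1OC` gives 20000 nM in this assay.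

Compound 3 carries the lowest of the three numbers, yet the steps of a 1.0-fold lower number from compound 1 to compound 3 (0.01 log units; within the scatter) and a 1.1-fold lower number from compound 2 to compound 3 (0.03 log units; within the scatter) both lie within the scatter, so the three compounds cannot be told apart on these data. Compound 4 `COc1cc(/C=C/C(=O)c2cc(-c3cc(OC)c(OC)c(OC)c3)n3nc(-c4ccccc4)cc3n2)cc(OC)c1OC` differs from compound 3 in one place: 3,4,5-trimethoxyphenyl in place of 4-methylphenyl on a double-bonded chain carbon bound to a double-bonded chain carbon. Both measured steps at this chain position, a ring swap and a methyl-for-methoxy exchange, left the read-out unchanged within the scatter. Because a 1.0-fold lower number from compound 1 to compound 3 (0.01 log units; within the scatter) and a 1.1-fold lower number from compound 2 to compound 3 (0.03 log units; within the scatter) showed no movement, the step of no change at the digits printed from compound 3 to compound 4 (within the scatter) is expected to stay within the scatter as well. Compound 4 is therefore estimated at 20000 nM, with a likely range from 8000 nM to 50000 nM.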

Compound 4, half-maximal inhibitory concentration: 25900 nM
The estimate for compound 4 lay 1.3-fold (0.11 log units) below the measured number; the measured number falls inside the stated range.
By their numbers in this assay, from the lowest: compounds 3, 1, 2 and 4 (each within the scatter of the next).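

On the double-bonded chain carbon, 3,4,5-trimethoxyphenyl reads the same within the scatter as 4-methylphenyl (a 1.3-fold higher number from compound 3 to compound 4 (0.11 log units; within the scatter)) and as 4-methoxyphenyl (a 1.2-fold higher number from compound 2 to compound 4 (0.09 log units; within the scatter)), and the same holds for the methoxy in place of hydrogen on an aromatic carbon (a 1.3-fold higher number from compound 1 to compound 4 (0.10 log units; within the scatter)). All four ring patterns at this position therefore remain indistinguishable, even with three methoxy groups on the ring. No outside measurement offers any explanation for this flat result.
Still open, going by these compounds, is whether a ring carrying an amine or a carboxylic acid at this position would shift the number in this assay beyond the scatter.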